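Moving a fluorine around the amide-bound phenyl ring

The compounds below may be only part of what the source reports. "The series", "measured", "known", "first", "only" and "open" are said of these compounds alone.

Three compounds share one core and differ only in the aromatic group on the amide nitrogen. Compound 1 `CCc1cccc(NC(=O)CN2CCC(c3cccc[n+]3[O-])CC2)c1` gives 62% in a functional assay on HEK293 cells for agonist activity at D(4) dopamine receptor (Homo sapiens), read by FLIPR; a lower number here means a smaller maximal response, a higher number a larger maximal response. Compound 2 `O=C(CN1CCC(c2cccc[n+]2[O-])CC1)Nc1cccc(F)c1` gives 70%, and compound 3 `O=C(CN1CCC(c2cccc[n+]2[O-])CC1)Nc1ccc(F)cc1` gives 71%, so compound 3 stands alongside the other two: a number 9 percentage points higher from compound 1 to compound 3 (within the scatter) and a number 1 percentage points higher from compound 2 to compound 3 (within the scatter). The next compound, compound 4 `O=C(CN1CCC(c2cccc[n+]2[O-])CC1)Nc1ccccc1F`, has not been measured. It differs from compound 3 by 2-fluorophenyl in place of 4-fluorophenyl on an amide-type nitrogen. The most closely related step, a number 1 percentage points higher from compound 2 to compound 3 (within the scatter), also only moved the fluorine on that ring, and the step of a number 8 percentage points higher from compound 1 to compound 2 (within the scatter) swapped groups on it; both stayed inside the scatter. The expected step is therefore a number 3 percentage points lower from compound 3 to compound 4 (within the scatter), with no change beyond the scatter, and compound 4 is estimated at 68%, within 55% to 82%.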

Compound 4, largest response reached (reported as efficacy), in percent of the reference or control that the assay uses: 63%
For compound 4 the middle estimate is 5 percentage points above the measured one, and the stated range covers the measured number.
By their numbers in this assay, from the lowest: compounds 1, 4, 2 and 3 (each within the scatter of the next).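

With 2-fluorophenyl on the amide-type nitrogen, the fluorine has now been seen in three ring placements in this assay, and no placement stands apart from another (the response is a number 8 percentage points lower from compound 3 to compound 4 (within the scatter) and a number 7 percentage points lower from compound 2 to compound 4 (within the scatter)). Exchanging 3-ethylphenyl for 2-fluorophenyl also stays inside the scatter (a number 1 percentage points higher from compound 1 to compound 4 (within the scatter)), so across these four compounds this position tolerates each of these groups with no clear difference in response. No measurement is available that would explain the small differences.

The compounds shown leave open whether a different kind of group on this ring, such as a carboxylic acid or an amine in place of the fluorine, would shift the response beyond the scatter.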